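The source may report more compounds than this note shows. Statements on the series, on what has been measured and on what is new or still open speak of the compounds shown alone.

Among the compounds with values here, compound 2 `O=C(/C(=C/c1ccccc1)CCl)c1ccccc1` stands at the low end of the two numbers so far. Within the data shown here, in a functional assay on HBL-100 cells (Homo sapiens) for inhibition, read by sulforhodamine B assay, with a stated time of 48 h (a higher number here means a weaker inhibitor of growth, a lower number a stronger inhibitor of growth), compound 2 gives 12000 nM, and its only neighbour, compound 1 `O=C(/C(=C/C1CCCCC1)CCl)c1ccccc1`, gives 22000 nM in this assay, so that the step of a 1.8-fold lower number from compound 1 to compound 2 (0.26 log units; within the scatter) lies within the scatter and the two compounds cannot be ranked against each other. Compound 3 `O=C(/C(=C/c1ccc(Cl)cc1)CCl)c1ccccc1` differs from compound 2 by chloro in place of hydrogen on an aromatic carbon. Among the measured compounds shown here, no measured step touches this aromatic ring itself: the single step recorded, from compound 1 to compound 2, exchanged a cyclohexyl for a phenyl and was itself within the scatter. With nothing to point either way, a step beyond the scatter in this assay is not expected, and the number for compound 3 is estimated to sit close to that of compound 2, the expected step being a 1.1-fold lower number from compound 2 to compound 3 (0.04 log units; within the scatter). Compound 3 is therefore expected to give about 11000 nM in this assay, within a range of 4000 nM to 30000 nM.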

Compound 3, concentration for 50% growth inhibition: 3200 nM
Beside the measured number, compound 3's estimate is 3.4-fold (0.54 log units) above it, and the stated range ends above it.
By their numbers in this assay, from the lowest: compound 3; then compounds 2 and 1 (each within the scatter of the next).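

Chloro in place of hydrogen on an aromatic carbon, para to a large group, produces the first step beyond the scatter in this assay, with a 3.8-fold lower number from compound 2 to compound 3 (0.57 log units; beyond the scatter) and a size rated modest. The earlier step, a 1.8-fold lower number from compound 1 to compound 2 (0.26 log units; within the scatter), could not rank its two compounds, whereas this result shows that the number responds to a single chlorine at this position of the aromatic ring. Nothing at hand accounts for why this change lowers the number.

On these data alone, it remains open whether this shift is particular to chloro or would also follow from another group at the same position, such as methoxy, an amine or a carboxylic acid. Also open, as far as these compounds go, is whether chloro would have a comparable effect on the other aromatic ring of the shared core.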